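The compounds below may be only part of what the source reports. "The series", "measured", "known", "first", "only" and "open" are said of these compounds alone.

Four compounds built on one shared core are considered here, and the question is how quickly liver enzymes break them down. The read-out is an ADME assay on microsomes from liver (Rattus norvegicus) for metabolic stability; on this read-out lower numbers stand for slow clearance and higher numbers for fast clearance. Compound 1, with the structure `CNc1nc(NC(C#N)(C2CC2)C2CC2)nc(-n2cncn2)n1`, gives 3.7 mL/min/kg in this assay. Compound 3, with the structure `CCC(C)(C#N)Nc1nc(NC)nc(-n2cncn2)n1`, gives 32 mL/min/kg. Compound 2, with the structure `CNc1nc(NC)nc(NC2(C#N)CCCCC2)n1`, gives 210 mL/min/kg, which is the highest of the three numbers: its gap to compound 3 and its wider gap to compound 1 both lie beyond the ordinary scatter of the measurement, so compound 2 is the one cleared fastest among the measured compounds.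

Compound 4, with the structure `CNc1nc(NC2(C#N)CCCCC2)nc(C2CC2)n1`, has not yet been measured. It differs from compound 2 in one place: cyclopropyl in place of methylamino on an aromatic carbon. Going by the values given here, no pair of measured compounds differs by exactly this change, so there is no measured step to lean on. A modest move toward slower clearance in this assay is expected, of size a 1.6-fold lower number from compound 2 to compound 4 (0.21 log units; within the scatter), though the data leave the direction uncertain. Compound 4 is therefore expected to show about 130 mL/min/kg, somewhere between 50 mL/min/kg and 300 mL/min/kg.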

Compound 4, clearance: 276 mL/min/kg
For compound 4 the middle estimate is 2.1-fold (0.33 log units) below the measured one; the measured number falls inside the stated range.
By their numbers in this assay, from the lowest: compound 1; then compound 3; then compounds 2 and 4 (each within the scatter of the next).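

Replacing methylamino with cyclopropyl on the aromatic carbon between two ring nitrogen atoms gives a 1.3-fold higher number from compound 2 to compound 4 (0.12 log units; within the scatter) in this assay and so leaves the two compounds indistinguishable on this read-out. Going by these compounds alone, this is the first measured step at this position, and it shows that a ring of carbon only, with no hydrogen-bond donor or acceptor, can take the place of methylamino here without a change that stands clear of the scatter. No evidence is available on why the two numbers lie so close.

From the compounds shown here alone, whether a dimethylamino group, a methoxy group or a longer carbon chain at this position would also read the same remains open. Going by these compounds, it is also open whether the same swap would give a similar step with different groups elsewhere on the shared core.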